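Working notes: 3,5-dichlorobenzyl to 4-methoxybenzyl

This account rests on a few compounds, and the source may have more. Where it says the series, first, only, none or still open, it means among the compounds named here.

In a functional assay on HeLa cells (Homo sapiens) for inhibition, read by sulforhodamine B assay, with a stated time of 72 h (on this read-out higher numbers stand for weaker inhibition of growth and lower numbers for stronger inhibition of growth), compound 1 (`O=C(NO)c1cnc(N2C[C@@H]3CN(S(=O)(=O)c4ccc(OC(F)(F)F)cc4)C[C@@H]3C2)nc1`) gives 940 nM and compound 2 (`COc1ccc2c(ccn2N2C[C@H]3CN(c4ncc(C(=O)NO)cn4)C[C@H]3C2)c1`) gives 230 nM while compound 3 (`O=C(NO)c1cnc(N2C[C@H]3CN(Cc4cc(Cl)cc(Cl)c4)C[C@H]3C2)nc1`) gives 940 nM on the same read-out. Compound 3 is thus level with compound 1, the pair holding the highest number of the three, and compound 2 lies lower by a margin beyond the scatter.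

Going by the values given here, compound 4 (`COc1ccc(CN2C[C@@H]3CN(c4ncc(C(=O)NO)cn4)C[C@@H]3C2)cc1`) keeps the shared core and differs from compound 3 by 4-methoxyphenyl in place of 3,5-dichlorophenyl on a saturated chain carbon bound to an amine nitrogen in a ring as the only change: 4-methoxyphenyl in place of 3,5-dichlorophenyl on a saturated chain carbon bound to an amine nitrogen in a ring.

Among the compounds with values here, no measured pair isolates a change of this kind. Compound 1 at 940 nM and compound 3 at 940 nM carry different groups on the core and still give the same number, so no step beyond the scatter is expected in this assay for this swap, perhaps only a slight move toward a lower number. The expected change is a 1.3-fold lower number from compound 3 to compound 4 (0.10 log units; within the scatter) and would remain inside the scatter. For compound 4 the estimated value is 750 nM with an expected range from 280 nM to 2000 nM on this read-out.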

Compound 4, concentration for 50% growth inhibition: 950 nM
Compound 4: middle estimate off by 1.3-fold (0.10 log units), on the low side; the measured number falls inside the stated range.
By their numbers in this assay, from the lowest: compound 2; then compounds 1, 3 and 4 (each within the scatter of the next).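

Going by these compounds alone, compound 3 and compound 4 form the first pair that differs in one place, and in this assay the swap gives a 1.0-fold higher number from compound 3 to compound 4 (0.00 log units; within the scatter). On a saturated chain carbon bound to an amine nitrogen in a ring, 3,5-dichlorophenyl and 4-methoxyphenyl therefore cannot be told apart on this read-out, even though the swap replaces both chlorine atoms and brings in the oxygen counted as a hydrogen-bond acceptor. No available evidence accounts for this equivalence.

Because the two groups differ in both the kind and the number of ring substituents, this single pair cannot separate those two changes, and 4-chlorophenyl or 3,5-dimethoxyphenyl would be needed to do so. From the compounds shown here alone, it also remains open whether this position stays equally flat with a phenyl ring carrying a carboxylic acid or an amine, or with a longer chain between the ring nitrogen and the phenyl ring.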